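One Added Methyl: From Ethylamino to Propylamino

A few compounds are considered here, and "the series" means these few. Any claim that something is new, unique, unknown or untested is made for them only; others in the source may bear on it.

Of the compounds shown here, three that share a core have been measured so far. In a functional assay on MCF7 cells (Homo sapiens) for antiproliferative activity (a lower number here means a stronger inhibitor, a higher number a weaker inhibitor), compound 1 `CC(C)=CCc1cc(C(=O)Nc2cc3ccc(OCCC4CCCCN4)c(C)c3oc2=O)ccc1O` gives 710 nM, compound 2 `CC(C)=CCc1cc(C(=O)Nc2cc3ccc(OCCCN4CCCC4)c(C)c3oc2=O)ccc1O` gives 990 nM and compound 3 `CCNCCCOc1ccc2cc(NC(=O)c3ccc(O)c(CC=C(C)C)c3)c(=O)oc2c1C` gives 980 nM. Compound 3 therefore sits within the scatter of both others, and these numbers do not separate the three.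

The next compound, compound 4 `CCCNCCCOc1ccc2cc(NC(=O)c3ccc(O)c(CC=C(C)C)c3)c(=O)oc2c1C`, differs from compound 3 in one place: methyl in place of hydrogen on a saturated chain carbon, two bonds along the chain from an amine nitrogen. This is methyl in place of hydrogen on a saturated chain carbon, two bonds along the chain from an amine nitrogen, so ethylamino becomes propylamino.

Within the data shown here, no measured step makes this exact change, but three steps alter the same amine-bearing group. Replacing piperidin-2-yl with (pyrrolidin-1-yl)methyl gives a 1.4-fold higher number from compound 1 to compound 2 (0.14 log units; within the scatter), and replacing it with (ethylamino)methyl gives a 1.4-fold higher number from compound 1 to compound 3 (0.14 log units; within the scatter). Ethylamino in place of pyrrolidin-1-yl gives a 1.0-fold lower number from compound 2 to compound 3 (0.00 log units; within the scatter). All three lie within the scatter, even though those changes are larger than a single methyl. The expected result in this assay is therefore no step beyond the scatter, with no favoured direction: the estimate is a 1.1-fold lower number from compound 3 to compound 4 (0.04 log units; within the scatter). For compound 4 the estimated value is 900 nM, with an expected range from 480 nM to 1700 nM.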

Compound 4, half-maximal inhibitory concentration: 980 nM
For compound 4 the middle estimate is 1.1-fold (0.04 log units) below the measured one, and the stated range covers the measured number.
By their numbers in this assay, from the lowest: compounds 1, 3, 4 and 2 (each within the scatter of the next).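

In this assay, lengthening ethylamino to propylamino by one methyl gives no change at the digits printed from compound 3 to compound 4 (within the scatter), so this step directly tests a small extension of the chain on the amine nitrogen, which the earlier, larger swaps of the whole amine-bearing group could not do. Propylamino also fits the picture set by those swaps, with a 1.0-fold lower number from compound 2 to compound 4 (0.00 log units; within the scatter) when it takes the place of pyrrolidin-1-yl and a 1.4-fold higher number from compound 1 to compound 4 (0.14 log units; within the scatter) when it takes the place of piperidin-2-yl , so all four compounds, whether their amine is open-chain or held in a ring, remain within the scatter of one another. Nothing available here explains why this added methyl leaves the number unmoved.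

Still open, going by these compounds, is whether a bulkier group on this nitrogen, such as a benzyl group, or a chain end with no amine at all, such as a carboxylic acid, would produce a step beyond the scatter. Also open, on these data alone, is what a longer chain between the amine nitrogen and the oxygen on the aromatic ring would do.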